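The source may hold more compounds than are shown below. What is called first, only, known or untested is meant among the compounds shown, and "the series" means these compounds.

Three compounds built around the same hydroxyphenyl-bearing chain have been examined in a functional assay on Jurkat cells (Homo sapiens) for cytotoxicity, with a stated time of 72 h; on this read-out lower numbers stand for an effect already at smaller amounts and higher numbers for an effect only at larger amounts of compound. Compound 1 `C=C[C@@](C)(/C=C/c1ccc(O)cc1)CC/C=C/C(=O)c1ccccc1` carries a benzoyl group on its chain, and in this assay compound 1 reaches only the limit of > 49000 nM, a limit rather than a number. Compound 2 `C=C[C@@](C)(/C=C/c1ccc(O)cc1)CC/C=C/C#N` differs from compound 1 by the change (cyano in place of benzoyl on a double-bonded chain carbon bound to a double-bonded chain carbon). In this assay compound 2 again stops at the limit of > 49000 nM, which is a limit and not a measured number. The step that the two limits leave unreadable from compound 1 to compound 2 therefore cannot be read. Compound 3 `C=C[C@@](C)(/C=C/c1ccc(O)c(/C=C/C(=O)c2ccccc2)c1)CCC=C(C)C` has a different core; how its core differs from that of compound 1 is not broken down here. In this assay compound 3 sits at the limit of > 49000 nM, once more a limit. All three values sit on the same boundary, which is the evidence given by the limit of > 49000 nM in this assay, at which 3 of the 3 values shown sit.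

Among the compounds with values here, compound 4 `C=C[C@@](C)(/C=C/c1ccc(O)c(/C=C/C#N)c1)CCC=C(C)C` is not yet measured and differs from compound 3 by the change (cyano in place of benzoyl on a double-bonded chain carbon bound to a double-bonded chain carbon), the same change as the one from compound 1 to compound 2. Within the data shown here, since every compound so far sits on the limit (the limit of > 49000 nM in this assay, at which 3 of the 3 values shown sit), the expected step that the limit leaves unreadable from compound 3 to compound 4 is estimated to be small, and compound 4 is expected to give about 80000 nM in this assay, most likely again reported only as a limit.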

Compound 4, half-maximal effective concentration: > 49000 nM
Compound 4: no number, only a limit; the forecaster's own chance of this, stated with the estimate: 85%; the middle value lies beyond the limit too.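

In this assay compound 4 gives > 49000 nM, which is a limit and not a number. Compound 3 also stops at a limit, so no step can be read from compound 3 to compound 4: the limit of > 49000 nM in this assay, at which 4 of the 4 values shown sit.

The compounds shown leave open whether cyano in place of benzoyl changes the effect on these cells at all, and how the four compounds rank against one another.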